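Branching the carbamate chain: propyl to isopropyl

A few compounds are considered here, and "the series" means these few. Any claim that something is new, unique, unknown or untested is made for them only; others in the source may bear on it.

Of the compounds shown here, three sharing one nucleoside core have been measured in an assay on DDT1 cells (Cricetulus griseus) for binding affinity to adenosine receptor A1 (Homo sapiens), read by radioligand binding; a lower number here means a stronger inhibitor, a higher number a weaker inhibitor. Compound 1 `C/N=C(\S)OC[C@H]1OC(n2cnc3c(NC4CCOC4)nc(Cl)nc32)[C@H](O)[C@@H]1O` gives 71 nM, and compound 2 `CC/N=C(\S)OC[C@H]1OC(n2cnc3c(NC4CCOC4)nc(Cl)nc32)[C@H](O)[C@@H]1O` gives 55 nM. For the measured compounds named here, the step of a 1.3-fold lower number from compound 1 to compound 2 (0.11 log units; within the scatter) is the only measured change of one group for another, and it lies within the scatter. Compound 3 `CCCNC(=O)OC[C@H]1OC(n2cnc3c(NC4CCOC4)ncnc32)[C@H](O)[C@@H]1O` gives 235 nM, the highest of the three numbers: its gap to compound 1 lies beyond the scatter, and its gap to compound 2 lies beyond the scatter as well.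

Compound 4 `CC(C)NC(=O)OC[C@H]1OC(n2cnc3c(NC4CCOC4)ncnc32)[C@H](O)[C@@H]1O` has the same atoms as compound 3, joined differently: isopropyl in place of propyl on an amide-type nitrogen. Going by the values given here, no measured step touches this carbamate chain; the only step on record, from compound 1 to compound 2, concerns a different part of the molecule and stayed within the scatter, so it gives no reason to expect a shift here either. The expectation for compound 4 is therefore a step of no change at the digits printed from compound 3 to compound 4 (within the scatter) that falls within the scatter in this assay. Compound 4 is estimated at 235 nM, with a range from 100 nM to 550 nM, before its own measurement is known.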

Compound 4, inhibition constant: 78 nM
Compound 4: the middle estimate sits 3.0-fold (0.48 log units) above what was measured, and the stated range ends above it.
By their numbers in this assay, from the lowest: compounds 2, 1 and 4 (each within the scatter of the next); then compound 3.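

In this assay, for the compounds shown here, the step of a 3.0-fold lower number from compound 3 to compound 4 (0.48 log units; beyond the scatter) is the first measured change on the carbamate chain, and it shows that the number at this position can respond to how the chain is joined. Isopropyl in place of propyl on an amide-type nitrogen moves the value beyond the scatter, although the two groups match in heavy-atom count and neither has a ring, a hydrogen-bond donor or acceptor, or a net charge. The compounds offer no measurement that explains why the branched chain gives the lower number.

The compounds shown leave open whether the trend would continue with a tert-butyl group or a cyclopropyl ring on the same nitrogen, or how a shorter ethyl or methyl chain would compare with propyl and isopropyl. They also leave open whether the same swap from propyl to isopropyl would give a similar step on a core bearing chlorine, as the cores of compound 1 and compound 2 do.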